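The compounds below may be only part of what the source reports. "The series", "measured", "known", "first", "only" and "open" are said of these compounds alone.

Measured in a functional assay on HCT-116 cells (Homo sapiens) for antiproliferative activity, read by MTT assay, with a stated time of 24 h; a higher number here means a weaker inhibitor, a lower number a stronger inhibitor:

- compound 1 `COc1ccc(-c2noc(C3CCCN3)n2)cc1OC1CCCC1`: 185000 nM
- compound 2 `Fc1ccc(-c2nc(-c3ccccc3)no2)cc1`: > 1000000 nM (a limit)

Among the compounds with values here, compound 1, at 185000 nM, holds the only number so far, so it has no numerical neighbour to be ranked against. Compound 2 reads > 1000000 nM, which is a limit and not a number.

The next compound is compound 3 `COc1ccc(-c2noc(-c3ccc(O)cc3)n2)cc1OC1CCCC1`. It has 4-hydroxyphenyl in place of pyrrolidin-2-yl on an aromatic carbon of the five-membered aromatic ring with 2 nitrogen and 1 oxygen, and the rest of compound 1 stays as it is: 4-hydroxyphenyl in place of pyrrolidin-2-yl on an aromatic carbon.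

Within the data shown here, no step between measured compounds is available to size this change. The expectation in this assay is therefore no shift beyond the scatter, in either direction, and the expected step, a 1.2-fold lower number from compound 1 to compound 3 (0.09 log units; within the scatter), is a cautious one. Compound 2 shows that this assay can end in a limit, with the limit of > 1000000 nM in this assay, at which 1 of the 2 values shown sits, so a limit reading for compound 3 is also expected to be possible.

For compound 3 the estimated value is 150000 nM, with an expected range of 40000 nM to 600000 nM.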

Compound 3, half-maximal inhibitory concentration: 270 nM
Compound 3: middle estimate off by 560-fold (2.74 log units), on the high side; the measured number lies below the stated range.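

In this assay, the aromatic carbon next to the ring nitrogen and next to the ring oxygen proves to be a position where the group strongly affects the read-out: 4-hydroxyphenyl in place of pyrrolidin-2-yl gives a 690-fold lower number from compound 1 to compound 3 (2.84 log units; beyond the scatter). The two groups have the same counts of hydrogen-bond donors and acceptors and no net charge, so those counts do not separate them, whereas their rings do differ, a five-membered non-aromatic ring with a hetero atom leaving and a six-membered aromatic ring of carbon only entering. Compound 2 still gives a limit and not a number: the limit of > 1000000 nM in this assay, at which 1 of the 3 values shown sits.

From the compounds shown here alone, whether the lower number comes from the aromatic ring itself or from its hydroxyl group remains open, and plain phenyl, 4-methoxyphenyl or 4-aminophenyl at this position would help to separate the two. Going by these compounds, the contribution of the cyclopentyl ether in the shared core also remains open, for instance in comparison with a simple methoxy group with 4-hydroxyphenyl kept in place.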